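The source may hold more compounds than are shown below. What is called first, only, known or untested is meant among the compounds shown, and "the series" means these compounds.

In a functional assay on HSC-4 cells (Homo sapiens) for cytotoxicity, with a stated time of 24 h (a higher number here means that more compound is tolerated, a lower number that less compound is tolerated), compound 1 `O=C1/C(=C/c2ccccc2)CCC/C1=C\c1ccc([N+](=O)[O-])cc1` gives 9200 nM, compound 2 `O=C1/C(=C/c2ccc(F)cc2)CCC/C1=C\c1ccc([N+](=O)[O-])cc1` gives 15000 nM and compound 3 `Cc1ccc(/C=C2\CCC/C(=C\c3ccc([N+](=O)[O-])cc3)C2=O)cc1` gives 13000 nM, so compound 3 cannot be told apart from the other two. Compound 4 `COc1ccc(/C=C2\CCC/C(=C\c3ccc([N+](=O)[O-])cc3)C2=O)cc1` differs from compound 3 in one place: methoxy in place of methyl on an aromatic carbon. This puts methoxy in place of methyl on an aromatic carbon, para to a large group. Three measured swaps on an aromatic carbon bear on this: a 1.6-fold higher number from compound 1 to compound 2 (0.21 log units; within the scatter), a 1.4-fold higher number from compound 1 to compound 3 (0.15 log units; within the scatter) and a 1.2-fold lower number from compound 2 to compound 3 (0.06 log units; within the scatter). Methoxy itself has not yet been measured in this series. Going by a 1.6-fold higher number from compound 1 to compound 2 (0.21 log units; within the scatter), the largest of the three, no shift beyond the scatter is expected in either direction, and the estimate amounts to a 1.1-fold lower number from compound 3 to compound 4 (0.03 log units; within the scatter). For compound 4 the estimated value is 12000 nM, with an expected range from 6500 nM to 22000 nM.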

Compound 4, half-maximal cytotoxic concentration: > 400000 nM
Compound 4 was reported as a limit; the forecaster's own chance of this, stated with the estimate: 3%; at least 33-fold (1.52 log units) between middle value and limit.
By their numbers in this assay, from the lowest: compounds 1, 3 and 2 (each within the scatter of the next). At a limit, above all of these: compound 4.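

Among hydrogen, fluoro and methyl at this place on the ring, the steps stay within the scatter, but methoxy breaks that flatness in this assay: an at least 30-fold higher number from compound 3 to compound 4 (1.48 log units; beyond the scatter), an at least 26-fold higher number from compound 2 to compound 4 (1.42 log units; beyond the scatter) and an at least 43-fold higher number from compound 1 to compound 4 (1.63 log units; beyond the scatter). This position is therefore not indifferent to its group, and the small change from 4-methylphenyl to 4-methoxyphenyl is enough to show it. Compound 4 stands at a limit, not at an exact number: the limit of > 400000 nM in this assay, at which 1 of the 4 values shown sits.

As far as these compounds go, how far compound 4 lies past that limit stays open. So does how a hydroxy, ethoxy or amine group would read at this place, and whether methoxy elsewhere on the ring would give the same jump.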